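The source may hold more compounds than are shown below. What is called first, only, known or untested is meant among the compounds shown, and "the series" means these compounds.

Compound 3, `CCCc1ccc(OCC(=O)N(CC)Cc2cccs2)cc1`, gives 1810 nM in an assay on HEK293 cells for agonist activity at transient receptor potential cation channel subfamily M member 8 (Homo sapiens), read by fluorescence and calcium flux, with a stated time of 15 min (a lower number here means that less compound is needed, a higher number that more compound is needed for the effect), the highest number among the three measured compounds. Compound 1, `CCN(Cc1cccs1)C(=O)COc1ccc(C(F)(F)F)cc1`, gives 236 nM, and compound 2, `CCc1ccc(OCC(=O)N(CC)Cc2cccs2)cc1`, gives 67 nM. Compound 4, `CCN(Cc1cccs1)C(=O)COc1ccccc1`, differs from compound 3 by hydrogen in place of propyl on an aromatic carbon; the place is on an aromatic carbon of a six-membered aromatic ring of carbon only, para to a large group.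

Going by the values given here, two measured steps bear on this change, and both concern the propyl group that compound 4 loses: a 7.7-fold higher number from compound 1 to compound 3 (0.88 log units; beyond the scatter) and a 27-fold higher number from compound 2 to compound 3 (1.43 log units; beyond the scatter). In each case the propyl group went with the higher number, whether the comparison was to the trifluoromethyl of compound 1 or to the ethyl of compound 2. Among the compounds with values here, no measured compound carries hydrogen at this position, so the size of the change is uncertain, but a move toward a lower number in this assay is expected, roughly a 6.0-fold lower number from compound 3 to compound 4 (0.78 log units; beyond the scatter). Compound 4 is therefore estimated at 300 nM, within a range from 60 nM to 1500 nM.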

Compound 4, half-maximal effective concentration: 1400 nM
Compound 4: middle estimate off by 4.7-fold (0.67 log units), on the low side; low and high end bracket the measured number.
By their numbers in this assay, from the lowest: compound 2; then compound 1; then compounds 4 and 3 (each within the scatter of the next).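

Putting hydrogen in place of propyl gives a 1.3-fold lower number from compound 3 to compound 4 (0.11 log units; within the scatter) in this assay, so at this place on the ring, propyl and hydrogen cannot be told apart. Hydrogen in place of ethyl gives a 21-fold higher number from compound 2 to compound 4 (1.32 log units; beyond the scatter) and hydrogen in place of trifluoromethyl gives a 5.9-fold higher number from compound 1 to compound 4 (0.77 log units; beyond the scatter), which shows that ethyl and trifluoromethyl go with lower numbers than the unsubstituted ring, while propyl, in compound 3, goes against that pattern. No measurement available here explains why ethyl and propyl part so sharply.

From the compounds shown here alone, whether a longer chain such as butyl would stay level with hydrogen, or a shorter group such as methyl would fall closer to ethyl, remains open. Going by these compounds, how an amine or a carboxylic acid at this place would compare is also open.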